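The source may report more compounds than this note shows. Statements on the series, on what has been measured and on what is new or still open speak of the compounds shown alone.

For the measured compounds named here, compound 3 `CN(C)c1ccc(C2=[N+]([O-])C(C)(C)C(C)(C)N2[O])cc1` gives 2.02 in a physicochemical assay for lipophilicity (a higher number here means a more lipophilic compound, a lower number a more polar compound), the top of the three numbers measured so far, although compound 2 `Cc1ccc(C2=[N+]([O-])C(C)(C)C(C)(C)N2[O])cc1` with 1.9 sits within the scatter of it, and compound 1 `CC1(C)N([O])C(c2ccc(O)cc2)=[N+]([O-])C1(C)C` gives 0.619. Compound 4 `CC1(C)N([O])C(c2ccc(Br)cc2)=[N+]([O-])C1(C)C` differs from compound 3 by bromo in place of dimethylamino on an aromatic carbon. The measured steps at this position are a number 1.28 log units higher from compound 1 to compound 2 (beyond the scatter), a number 1.40 log units higher from compound 1 to compound 3 (beyond the scatter) and a number 0.12 log units higher from compound 2 to compound 3 (within the scatter): removing hydroxy raised the number sharply, whereas swapping methyl for dimethylamino left it unchanged. Going by the values given here, no measured step involves bromo, so the size can only be inferred loosely. The step is therefore expected to be small and upward, a number 0.28 log units higher from compound 3 to compound 4 (within the scatter). Compound 4 is estimated at 2.3, with a range from 1.9 to 2.7.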

Compound 4, partition coefficient: 2.46
Beside the measured number, compound 4's estimate is 0.16 log units below it, within the range that was stated.
By their numbers in this assay, from the lowest: compound 1; then compounds 2 and 3 (each within the scatter of the next); then compound 4.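

In this assay, for the compounds shown here, bromo is the first replacement for methyl or dimethylamino that moves the number beyond the scatter, with a number 0.44 log units higher from compound 3 to compound 4 (beyond the scatter) and a number 0.56 log units higher from compound 2 to compound 4 (beyond the scatter) while those two groups stay within the scatter of each other. Hydroxy remains well apart from all three other groups, and the widest step is a number 1.84 log units higher from compound 1 to compound 4 (beyond the scatter) at this aromatic carbon. Nothing measured here accounts for this order among the groups. From the compounds shown here alone, it remains open where chloro, a nitrile, a carboxylic acid or a longer chain would fall at this place, and whether the order of these groups would hold on another core.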